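Fluoro Removed on the Core: Cytotoxicity of Compound 4

The compounds below may be only part of what the source reports. "The series", "measured", "known", "first", "only" and "open" are said of these compounds alone.

Compound 1 `NC(=O)c1nccnc1O` gives > 250000 nM in an ADME assay on MDCK cells (Canis lupus familiaris) for cytotoxicity, read by microscopy, with a stated time of 3 days (a lower number here means that less compound is tolerated, a higher number that more compound is tolerated), which is a limit of the assay and not a number.
Compound 2 `NC(=O)c1nc(F)cnc1O` gives > 250000 nM in this assay, again a limit.
Compound 3 `CCCCCCCCCCCCCCC(=O)Oc1ccc(COP(=O)(OCc2ccc(OC(=O)CCCC)cc2)OP(=O)(O)OC[C@H]2O[C@@H](n3cc(F)nc(C(N)=O)c3=O)[C@H](O)[C@@H]2O)cc1` gives 21000 nM in this assay.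

Compound 1 and compound 2 differ by hydrogen in place of fluoro on an aromatic carbon. The step that the two limits leave unreadable from compound 2 to compound 1 cannot be read, because both values sit at the limit of > 250000 nM in this assay, at which 2 of the 3 values shown sit. Compound 3 carries a much larger substituent, and how its core differs from the core of compound 2 is not broken down here; compound 3 is the only one of the three with a definite number.

Compound 4 `CCCCCCCCCCCCCCC(=O)Oc1ccc(COP(=O)(OCc2ccc(OC(=O)CCCC)cc2)OP(=O)(O)OC[C@H]2O[C@@H](n3ccnc(C(N)=O)c3=O)[C@H](O)[C@@H]2O)cc1`, still unmeasured, stands to compound 3 as compound 1 stands to compound 2: hydrogen in place of fluoro on an aromatic carbon. The two place descriptions are not identical, since in compound 2 the fluoro is para to a hydroxy group, whereas in compound 3 it is meta to a large group and para to a group of 1 heavy atom, so this is the same kind of change rather than the same one. With the measured step unreadable, compound 4 is expected to stay close to compound 3, a step of no change at the digits printed from compound 3 to compound 4 (within the scatter). Compound 4 is therefore estimated at 21000 nM, between 8000 nM and 60000 nM.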

Compound 4, minimum cytotoxic concentration: 21000 nM
Estimate against measurement, compound 4: no gap at the digits printed; low and high end bracket the measured number.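

In this assay, hydrogen in place of fluoro on an aromatic carbon gives no change at the digits printed from compound 3 to compound 4 (within the scatter), so on this large core the change leaves no mark at the digits printed. The same change from compound 2 to compound 1 cannot be read, since compound 1 and compound 2 both stand at a limit of the assay and not at a number: the limit of > 250000 nM in this assay, at which 2 of the 4 values shown sit. The series therefore offers one readable case of this change, which shows what happens on the core of compound 3 but does not show that the two cores respond alike, so no agreement between them can be claimed.

The compounds shown leave open whether another group in the same place, such as chloro, methyl or an amine, would read as fluoro and hydrogen do here. They also leave open whether a carboxylic acid in place of the carbamoyl group, or a shorter or longer chain on the ester groups, would move the value away from compound 4 at 21000 nM.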